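The source may hold more compounds than are shown below. What is called first, only, known or untested is meant among the compounds shown, and "the series" means these compounds.

In a functional assay on KB-V1 cells (Homo sapiens) for cytotoxicity, read by MTT assay, with a stated time of 72 h (a higher number here means a weaker inhibitor, a lower number a stronger inhibitor), compound 1 (`O=C1Nc2ccccc2/C1=N/NC(=S)Nc1ccccc1`) gives 1470 nM and compound 2 (`COc1ccccc1NC(=S)N/N=C1\C(=O)Nc2ccccc21`) gives 2690 nM. For the measured compounds named here, compound 1 therefore stands within the scatter of the only other measured compound, and the two numbers cannot be told apart. The next entry is compound 3 (`O=C1Nc2ccccc2/C1=N/NC(=S)Nc1ccc(C(F)(F)F)cc1`), which keeps the core of compound 1 and has trifluoromethyl in place of hydrogen on an aromatic carbon, para to a large group: trifluoromethyl in place of hydrogen on an aromatic carbon. Going by the values given here, the one measured step that bears on this is methoxy in place of hydrogen on an aromatic carbon, a 1.8-fold higher number from compound 1 to compound 2 (0.26 log units; within the scatter). It involves another group, and a single step gives only weak guidance, so no step beyond the scatter is expected in this assay. The estimate means a 1.1-fold lower number from compound 1 to compound 3 (0.05 log units; within the scatter), an expected step of no clear direction. The estimated value for compound 3 is 1300 nM, with an expected range from 450 nM to 3800 nM.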

Compound 3, half-maximal inhibitory concentration: 2100 nM
Compound 3: the middle estimate sits 1.6-fold (0.21 log units) below what was measured, and the stated range covers the measured number.
By their numbers in this assay, from the lowest: compounds 1, 3 and 2 (each within the scatter of the next).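

In this assay, trifluoromethyl in place of hydrogen on an aromatic carbon, para to a large group, gives a 1.4-fold higher number from compound 1 to compound 3 (0.15 log units; within the scatter) and so adds a group of 4 heavy atoms at this place without a step beyond the scatter. With the methoxy change, which gives a 1.8-fold higher number from compound 1 to compound 2 (0.26 log units; within the scatter), two replacements of hydrogen on an aromatic carbon now leave the number within the scatter of compound 1, although this holds only for these two groups. No measurement at hand bears on why this step is small.

Still open, from the compounds shown here alone, is whether an amine, a carboxylic acid or a longer alkyl chain at this same place would produce a step beyond the scatter. Also open, going by these compounds, is how the number responds to a change in the shared core rather than on this aromatic ring.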